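Swapping Methoxy for Chloro on a Shared Scaffold

This account rests on a few compounds, and the source may have more. Where it says the series, first, only, none or still open, it means among the compounds named here.

Compound 1, `Nc1cccc(-c2cn3nc(Cc4ccc(Cl)cc4)sc3n2)c1`, gives 16000 nM.
Compound 2, `COc1ccc(Cc2nn3cc(-c4cccc(N)c4)nc3s2)cc1`, gives 227000 nM.
Compound 3, `C=C(Br)C(=O)Nc1cccc(-c2cn3nc(-c4ccc(OC)cc4)sc3n2)c1`, gives 940 nM.

All three were tested in a functional assay on L1210 cells (Mus musculus) for inhibition, read by cell counting, with a stated time of 2 days; on this read-out lower numbers stand for stronger inhibition and higher numbers for weaker inhibition. Compound 2 shows the highest number of the three, and the step of a 14-fold lower number from compound 2 to compound 1 (1.15 log units; beyond the scatter) shows how much one small change moved the read-out; that change is chloro in place of methoxy on an aromatic carbon. Compound 3 carries a different core from compound 2, and the difference between the two cores is not broken down here. In this assay compound 3 stands lowest of the three numbers, clearly apart from compound 1 and still further from compound 2.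

Compound 4, `C=C(Br)C(=O)Nc1cccc(-c2cn3nc(-c4ccc(Cl)cc4)sc3n2)c1`, has not yet been measured in this assay. Among the compounds with values here, it differs from compound 3 by chloro in place of methoxy on an aromatic carbon, which is the same change as the one between compound 2 and compound 1, made at the same kind of place. Because the earlier step of a 14-fold lower number from compound 2 to compound 1 (1.15 log units; beyond the scatter) was large, the step of a 4.9-fold lower number from compound 3 to compound 4 (0.69 log units; beyond the scatter) is expected to run in the same direction, though a somewhat smaller step is assumed, since the two cores differ and the earlier step rests on a single pair. For compound 4 the expected value in this assay is 190 nM, with a likely range from 60 nM to 600 nM.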

Compound 4, half-maximal inhibitory concentration: 1400 nM
For compound 4 the middle estimate is 7.4-fold (0.87 log units) below the measured one, and the stated range ends below it.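

In this assay, the step of a 1.5-fold higher number from compound 3 to compound 4 (0.17 log units; within the scatter) lies within the usual scatter, so on this core, putting chloro in place of methoxy shows no readable effect. The same swap on the other core gave a large step, and the two results clearly disagree: the same change on two cores in this assay, a 14-fold lower number (1.15 log units; beyond the scatter) from compound 2 to compound 1 and a 1.5-fold higher number (0.17 log units; within the scatter) from compound 3 to compound 4, 21-fold (1.32 log units) apart, beyond the scatter of two such steps. Within the data shown here, this shows that the size of the step seen on one core cannot simply be carried over to another core, but it does not show which structural difference between the two pairs is responsible, since the pairs differ in more than one place and each core offers only a single pair.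

The compounds shown leave open whether other groups at this same place on the six-membered aromatic ring, such as fluoro, methyl or a nitrile, would also give a large step on one core and almost none on the other. They also leave open how the swap would behave on a further core, for instance one carrying a carboxylic acid in place of the amine of compound 1, and whether either of the two steps is the more typical one.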